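Chloro entering the aryl ring of compound 1

The source may hold more compounds than are shown below. What is called first, only, known or untested is meant among the compounds shown, and "the series" means these compounds.

Within the data shown here, compound 1 `COc1ccc(/C=C2/C(=O)N(c3ccc(Cl)cc3)N=C2C)cc1OC` gives 2030 nM in an assay for inhibition of Alpha amylase (Homo sapiens), with a stated time of 10 min (a lower number here means a stronger inhibitor, a higher number a weaker inhibitor), one of only two numbers so far; compound 2 `COc1cc(/C=C2/C(=O)N(c3ccc(Cl)cc3)N=C2C)cc(OC)c1OC` gives 2190 nM, and the step of a 1.1-fold higher number from compound 1 to compound 2 (0.03 log units; within the scatter) is too small to read. Compound 3 `COc1ccc(/C=C2/C(=O)N(c3ccc(Cl)cc3)N=C2C)c(Cl)c1OC` differs from compound 1 by chloro in place of hydrogen on an aromatic carbon. Among the measured compounds shown here, the only measured step, a methoxy entering an aromatic carbon, moved nothing beyond the scatter; a chloro entering an aromatic carbon is a different change, and nothing in hand argues for a large step in this assay either way. Compound 3 is therefore estimated at 2000 nM, a step of a 1.0-fold lower number from compound 1 to compound 3 (0.01 log units; within the scatter), with a range from 800 nM to 5000 nM.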

Compound 3, half-maximal inhibitory concentration: 1970 nM
Compound 3: middle estimate off by 1.0-fold (0.01 log units), on the high side, and the stated range covers the measured number.
By their numbers in this assay, from the lowest: compounds 3, 1 and 2 (each within the scatter of the next).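

In this assay chloro in place of hydrogen on the aromatic carbon ortho to a large group and ortho to a methoxy group gives no readable shift (a 1.0-fold lower number from compound 1 to compound 3 (0.01 log units; within the scatter)). This position therefore accepts a chloro with the number staying within the scatter of compound 1, as it also does for compound 2 with its added methoxy at another aromatic carbon. Nothing available accounts for this flat response.

On these data alone, whether an amine, a carboxylic acid or a longer chain at this aromatic carbon would move the number beyond the scatter remains open. So does the effect of changes elsewhere on the core of compound 1.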